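From difluorobenzyl to dichlorobenzyl: one halogen swap

A few compounds are considered here, and "the series" means these few. Any claim that something is new, unique, unknown or untested is made for them only; others in the source may bear on it.

Compound 1 `O=C(Nc1ccc(-c2cscn2)cc1)C1CCCN(Cc2ccc(F)c(F)c2)C1`: 880 nM
Compound 2 `O=C(Nc1ccc2scnc2c1)C1CCCN(Cc2ccc(F)c(F)c2)C1`: > 20000 nM (a limit of the assay)
Compound 3 `O=C(Nc1ccc(-c2cscn2)cc1)C1CCCN(Cc2cc(F)c(F)c(F)c2)C1`: 400 nM

In a functional assay on A-375 cells (Homo sapiens) for antiproliferative activity (a higher number here means a weaker inhibitor, a lower number a stronger inhibitor), compound 1 gives 880 nM, the higher of the two actual numbers in this small set. The other number belongs to compound 3, at 400 nM. Compound 2 reads > 20000 nM, which is a limit and not a number.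

Compound 4 `O=C(Nc1ccc(-c2cscn2)cc1)C1CCCN(Cc2ccc(Cl)c(Cl)c2)C1` has not yet been measured. It departs from compound 1 in one group: 3,4-dichlorophenyl in place of 3,4-difluorophenyl on a saturated chain carbon bound to an amine nitrogen in a ring. This puts 3,4-dichlorophenyl in place of 3,4-difluorophenyl on a saturated chain carbon bound to an amine nitrogen in a ring.

Going by the values given here, only one measured step touches this group, and it is not the same change. It is a 2.2-fold lower number from compound 1 to compound 3 (0.34 log units; beyond the scatter), with fluoro in place of hydrogen on an aromatic carbon. Among the compounds with values here, compound 2 offers no measured step on this group. On that single modest precedent, a small move toward a lower number in this assay is expected, and it may not clear the scatter. The expected step is a 1.8-fold lower number from compound 1 to compound 4 (0.25 log units; within the scatter). Compound 4 is estimated at 500 nM, with an expected range from 150 nM to 1600 nM.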

Compound 4, half-maximal inhibitory concentration: 1730 nM
Estimate against measurement, compound 4: 3.5-fold (0.54 log units) below; the whole stated range lies below it.
By their numbers in this assay, from the lowest: compound 3; then compounds 1 and 4 (each within the scatter of the next). At a limit, above all of these: compound 2.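

Exchanging the two fluorines of compound 1 for chlorines gave a 2.0-fold higher number from compound 1 to compound 4 (0.29 log units; within the scatter) in this assay and so left the two compounds indistinguishable, which shows that the 3,4-difluorophenyl group can give way to 3,4-dichlorophenyl at this place without a reading that can be told apart from the parent. The earlier compounds had shown only that adding a fluorine mattered, and that precedent does not carry over to this halogen swap, since the 3,4-dichlorophenyl compound falls in with compound 1 and not with compound 3. The comparison with the trifluorinated compound gives a 4.3-fold higher number from compound 3 to compound 4 (0.64 log units; beyond the scatter) and is a modest step beyond the scatter, so among these three compounds, which differ only in this group, 3,4,5-trifluorophenyl alone stands apart from the other two.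

As far as these compounds go, what a single chlorine, a 3,4,5-trichlorophenyl group, or a methoxy or trifluoromethyl group on this phenyl ring would give remains open. Nothing shown here offers a measured property that would account for these steps.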